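The source may report more compounds than this note shows. Statements on the series, on what has been measured and on what is new or still open speak of the compounds shown alone.

Measured so far in an assay on isolated protein for inhibition of metabotropic glutamate receptor 5 (Homo sapiens), tested at 10 uM; a lower number here means less inhibition, a higher number more inhibition at the concentration tested (going by the name of the read-out):
compound 1 `Cc1ccc(C(=O)COC(=O)c2ccc(N3C(=O)C4=C(CCC4)C3=O)cc2)cc1C`, compound 1 gives 10%
compound 2 `Cc1ccc(C(=O)COC(=O)c2ccc(N3C(=O)c4ccncc4C3=O)cc2)cc1C`, compound 2 gives 33%

Compound 1 stands lowest of the two numbers; its nearest neighbour is compound 2, whose value lies higher by a gap beyond the scatter. Among the compounds with values here, no step between these two compounds is counted here, so only their two values speak.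

Compound 3 `Cc1ccc(C(=O)COC(=O)c2ccc(N3CCCC3=O)cc2)cc1C` has not been measured in this assay. Its difference from compound 1 is a group of 6 heavy atoms (4 carbon, 1 nitrogen, 1 oxygen; one five-membered non-aromatic ring with 1 hetero atom) in place of a group of 10 heavy atoms (7 carbon, 1 nitrogen, 2 oxygen; one five-membered non-aromatic ring of carbon only, one five-membered non-aromatic ring with 1 hetero atom), on an aromatic carbon. The group that leaves is the larger of the two; what enters keeps one five-membered non-aromatic ring with one hetero atom and one hydrogen-bond acceptor, at the same aromatic carbon, para to a large group.

Within the data shown here, with both measured values low and no counted step to lean on, the expected step is small, in no clear direction, and not beyond the scatter: a number 2 percentage points higher from compound 1 to compound 3 (within the scatter) is the estimate. Compound 3 is expected near 12%, in the range 0% to 30%.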

Compound 3, a percentage reported as inhibition, at one concentration (the size of the read-out at that concentration, not a potency): 38%
Compound 3: middle estimate off by 26 percentage points, on the low side, outside the stated range (above it).
By their numbers in this assay, from the lowest: compound 1; then compounds 2 and 3 (each within the scatter of the next).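

In this assay the replacement of the larger group on the aromatic carbon, para to a large group, by 2-oxopyrrolidin-1-yl gives a number 28 percentage points higher from compound 1 to compound 3 (beyond the scatter) and shows that this position accepts a smaller group without any loss of inhibition. The group that enters keeps one five-membered non-aromatic ring with 1 hetero atom, so the five-membered ring of carbon only is not needed for inhibition at the concentration tested. Nothing measured on these compounds tells why the number rises with this change.

Going by these compounds, whether a simpler open-chain group at this aromatic carbon, such as an acetamide or a primary amine, would hold the number remains open. Also open, on these data alone, is whether these single-concentration readings would carry over to a ranking by potency.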